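Aryl swap on the shared core, from compound 2 to compound 4

This account rests on a few compounds, and the source may have more. Where it says the series, first, only, none or still open, it means among the compounds named here.

Compound 1 `Cc1ccc(Nc2cc(NC(=O)Nc3c(Cl)cccc3Cl)ncn2)cc1F`: 33.5%
Compound 2 `COc1cc(NC(=O)Nc2cc(Nc3cccc(C(C)(C)C)c3)ncn2)cc(OC)c1`: 13.1%
Compound 3 `COc1ccc(Br)cc1Nc1cc(NC(=O)Nc2c(Cl)cccc2Cl)ncn1`: 45%

In a functional assay on NCI-H520 cells (Homo sapiens) for inhibition, read by MTT assay, with a stated time of 48 h, tested at 10 uM (on this read-out higher numbers stand for more inhibition at the one concentration tested (going by the name of the read-out) and lower numbers for less inhibition), compound 2 gives the lowest of the three numbers, below compound 1 and well below compound 3. Compound 4 `COc1cc(NC(=O)Nc2cc(Nc3cc(I)ccc3OC)ncn2)cc(OC)c1` differs from compound 2 in one place: 5-iodo-2-methoxyphenyl in place of 3-(tert-butyl)phenyl on a nitrogen on an aromatic ring. Among the compounds with values here, the only measured step of a related kind is a number 11.5 percentage points higher from compound 1 to compound 3 (beyond the scatter), where a halogen-bearing methoxyphenyl likewise entered on the same nitrogen and the number rose modestly. Within the data shown here, on that basis compound 4 is expected to show a rise of similar size over compound 2, about a number 11.9 percentage points higher from compound 2 to compound 4 (beyond the scatter), though the low starting point of compound 2 and the single supporting step leave the range wide. The estimate for compound 4 in this assay is 25%, between 10% and 42%.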

Compound 4, a percentage reported as inhibition, at one concentration (the size of the read-out at that concentration, not a potency): 55%
The estimate for compound 4 lay 30 percentage points below the measured number; the whole stated range lies below it.
By their numbers in this assay, from the lowest: compound 2; then compound 1; then compounds 3 and 4 (each within the scatter of the next).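

In this assay, the swap at this position gives a number 41.9 percentage points higher from compound 2 to compound 4 (beyond the scatter), a large step, whereas a number 11.5 percentage points higher from compound 1 to compound 3 (beyond the scatter) was only modest. The nitrogen on the aromatic ring can therefore carry a far bigger change than the earlier pair showed, and here it does so with the other aryl group of compounds 2 and 4 in place. Nothing at hand explains the size of this step.

As far as these compounds go, it remains open which part of 5-iodo-2-methoxyphenyl goes with the rise, the iodine or the methoxy group. From the compounds shown here alone, how an amine or a carboxylic acid on that phenyl ring would read also stays unknown.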